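Replacing cyanomethyl with 2,4-dichlorobenzyl on the shared core

The compounds below may be only part of what the source reports. "The series", "measured", "known", "first", "only" and "open" are said of these compounds alone.

Measured in an ADME assay on MT4 cells (Homo sapiens) for cytotoxicity, read by MTT assay, with a stated time of 5 days; a lower number here means that less compound is tolerated, a higher number that more compound is tolerated:
- compound 1, `N#CCN1C(=O)N(Cc2cccc(F)c2)S(=O)(=O)n2cccc21`: compound 1 gives 172000 nM
- compound 2, `N#Cc1ccccc1CN1C(=O)N(Cc2ccccc2)S(=O)(=O)n2cccc21`: compound 2 gives > 318000 nM, which is a limit of the assay and not a number
- compound 3, `N#CCN1C(=O)N(Cc2ccccc2)S(=O)(=O)n2cccc21`: compound 3 gives 180000 nM

Among the two numbers, compound 1 holds the lowest, and compound 3 sits within the scatter of it, as a 1.0-fold higher number from compound 1 to compound 3 (0.02 log units; within the scatter) shows. Among the measured compounds shown here, the limit for compound 2 is the only other value, (the limit of > 318000 nM in this assay, at which 1 of the 3 values shown sits).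

Compound 4, `O=C1N(Cc2ccc(Cl)cc2Cl)c2cccn2S(=O)(=O)N1Cc1cccc(F)c1`, differs from compound 1 by 2,4-dichlorophenyl in place of cyano on a saturated chain carbon bound to an amide-type nitrogen in a ring. The nearest measured step at this place is an at least 1.7-fold lower number from compound 2 to compound 3 (0.24 log units; that floor lies within the scatter), which reaches only a floor that lies within the scatter; the step of a 1.0-fold higher number from compound 1 to compound 3 (0.02 log units; within the scatter) concerns a different position and is within the scatter too. For the measured compounds named here, no measured step therefore points to a change beyond the scatter, in either direction. Compound 4 is expected to give 160000 nM in this assay, between 50000 nM and 400000 nM, which as a step means a 1.1-fold lower number from compound 1 to compound 4 (0.03 log units; within the scatter), an expected change that stays within the scatter.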

Compound 4, half-maximal cytotoxic concentration: > 249000 nM
Compound 4: only a limit was reported; the forecaster's own chance of this, stated with the estimate: 25%; middle value at least 1.5-fold (0.19 log units) away from the limit.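

In this assay compound 4 gives > 249000 nM, which is a limit of the assay and not a number. Putting 2,4-dichlorophenyl in place of cyano on a saturated chain carbon bound to an amide-type nitrogen in a ring thus gives an at least 1.4-fold higher number from compound 1 to compound 4 (0.16 log units; that floor lies within the scatter) and shows that this much larger aromatic group brings no measurable fall in the number, although the floor of the step does not establish a rise beyond the scatter. Compound 2, which carries 2-cyanophenyl at this place, also ends in a limit: the limit of > 318000 nM in this assay, at which 1 of the 4 values shown sits.

On these data alone, how far compound 4 lies past its limit stays open, so the true size of this step is unknown. Also open, as far as these compounds go, is how an amine, a carboxylic acid or a longer chain at this place would read in this assay and whether any such group would bring the number down.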